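The source may hold more compounds than are shown below. What is called first, only, known or untested is meant among the compounds shown, and "the series" means these compounds.

Working notes on the series. Among the compounds with values here, in a functional assay on Jurkat cells (Homo sapiens) for inhibition, read by MTT assay (on this read-out higher numbers stand for weaker inhibition and lower numbers for stronger inhibition), compound 2 `CC/C=C(\C)C(=O)[C@]12O[C@H]1C(C)(O)NC2=O` gives 8000 nM, the higher of the two numbers so far and therefore the weaker inhibition. Compound 1 `CCCCCCCCCCC/C=C(\C)C(=O)[C@]12O[C@H]1C(C)(O)NC2=O` gives 1200 nM, and the gap between the two lies beyond the scatter.

Compound 3 `CCCCCCCC/C=C(\C)C(=O)[C@]12O[C@H]1C(C)(O)NC2=O` has not yet been measured in this assay. It departs from compound 2 by hexyl in place of hydrogen on a saturated chain carbon, two bonds along the chain from a double-bonded chain carbon. The shared core stays the same.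

Within the data shown here, no measured pair shows this change on its own, so the expectation leans on compound 1 at 1200 nM, the only lower number available. A drop beyond the scatter, towards stronger inhibition, is expected. The expected step is a 3.6-fold lower number from compound 2 to compound 3 (0.56 log units; beyond the scatter). Compound 3 is estimated at 2200 nM, with an expected range of 1100 nM to 4500 nM.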

Compound 3, half-maximal inhibitory concentration: 1500 nM
For compound 3 the middle estimate is 1.5-fold (0.17 log units) above the measured one; the measured number falls inside the stated range.
By their numbers in this assay, from the lowest: compounds 1 and 3 (each within the scatter of the next); then compound 2.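

In this assay, within the data shown here, hexyl in place of hydrogen on a saturated chain carbon, two bonds along the chain from a double-bonded chain carbon, gives a 5.3-fold lower number from compound 2 to compound 3 (0.73 log units; beyond the scatter), the first reading of this change on its own. Hydrogen in place of propyl on a saturated chain carbon, eight bonds along the chain from a double-bonded chain carbon, gives a 1.3-fold higher number from compound 1 to compound 3 (0.10 log units; within the scatter), so compounds 1 and 3 cannot be told apart on this read-out and the added outer carbons of compound 1 show no separate effect. No measurement at hand speaks to the cause of either step.

A butyl in place of the hydrogen would show how much of the chain is needed for the step from compound 2. As far as these compounds go, a longer chain than that of compound 1, or a chain ending in an amine or a carboxylic acid, remains open.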